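A few compounds are considered here, and "the series" means these few. Any claim that something is new, unique, unknown or untested is made for them only; others in the source may bear on it.

Of the compounds shown here, three sharing one core have been read in an ADME assay on HepG2 cells (Homo sapiens) for inhibition, read by fluorescence and resazurin assay, with a stated time of 72 h; on this read-out lower numbers stand for stronger inhibition and higher numbers for weaker inhibition. Compound 1 (`Cc1ccc(Nc2nccc(Nc3ccc4nc[nH]c4c3)n2)cc1`) gives only a limit, > 25000 nM. Compound 2 (`CN1CCN(c2ccc(Nc3nccc(Nc4ccc5nc[nH]c5c4)n3)cc2)CC1`) also gives only a limit, > 25000 nM. Compound 3 (`Cc1cc(Nc2nccc(Nc3ccc4nc[nH]c4c3)n2)ccc1N1CCN(C)CC1`) gives a number, 15000 nM. Compound 2 therefore has no number of its own and stands at the limit of > 25000 nM in this assay, at which 2 of the 3 values shown sit.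

Compound 4 (`NS(=O)(=O)c1ccc(Nc2nccc(Nc3ccc4nc[nH]c4c3)n2)cc1`) differs from compound 2 by sulfamoyl in place of 4-methylpiperazin-1-yl on an aromatic carbon, para to a large group: sulfamoyl in place of 4-methylpiperazin-1-yl on an aromatic carbon. Among the measured compounds shown here, two measured steps bear on this change. The exchange that brings in 4-methylpiperazin-1-yl in place of methyl is a step that the two limits leave unreadable from compound 1 to compound 2. Sulfamoyl enters in neither step, and with an at least 1.6-fold lower number from compound 2 to compound 3 (0.22 log units; that floor lies within the scatter) as the only step with any size, no shift beyond the scatter is expected in this assay. The expected step is a number no higher from compound 2 to compound 4 (the limit leaves the size open). Compound 4 is estimated at 25000 nM, with an expected range from 10000 nM to 50000 nM, and another limit would be no surprise.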

Compound 4, half-maximal inhibitory concentration: > 25000 nM
Compound 4 was reported as a limit; the forecaster's own chance of this, stated with the estimate: 65%; the middle value sits exactly at the limit.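

In this assay compound 4 gives > 25000 nM, which is a limit, so neither its step from compound 1 nor its step from compound 2 can be read. The compounds shown leave open whether sulfamoyl in place of 4-methylpiperazin-1-yl changes the number at all, and in which direction.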